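A cyclopropyl swap in a cell tolerance test

The source may hold more compounds than are shown below. What is called first, only, known or untested is meant among the compounds shown, and "the series" means these compounds.

Compound 1 `O=S(=O)(CCCCl)N1CCC2(CC1)OOC1(CCCC1)OO2`: > 100 ug/mL
Compound 2 `CCCS(=O)(=O)N1CCC2(CC1)OOC(C)(C)OO2`: > 100 ug/mL

Both results come from a functional assay on Huh-7 cells (Homo sapiens) for cytotoxicity, read by MTT assay, with a stated time of 72 h; a lower number here means that less compound is tolerated, a higher number that more compound is tolerated. Compound 1 gives > 100 ug/mL, which is a limit of the assay and not a number. Compound 2 gives > 100 ug/mL, which is also only a limit. The whole picture so far is the limit of > 100 ug/mL in this assay, at which 2 of the 2 values shown sit, so compound 2 has no exact place on the scale.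

Compound 3 `CCCS(=O)(=O)N1CCC2(CC1)OOC(C)(C1CC1)OO2` is made from compound 2 by a single change: cyclopropyl in place of methyl on a saturated ring carbon. This puts cyclopropyl in place of methyl on a saturated ring carbon, between two ring oxygen atoms.

For the measured compounds named here, no measured pair shows what a change at this place does in this assay. The expectation therefore rests on compound 2 and its limit of > 100 ug/mL. No step beyond the scatter is expected, and no direction can be favoured. The expected size of the change is a step that the limit leaves unreadable from compound 2 to compound 3. Another result reported only as a limit is also likely. Compound 3 is estimated at 130 ug/mL, with an expected range of 60 ug/mL to 280 ug/mL.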

Compound 3, half-maximal cytotoxic concentration: > 100 ug/mL
Compound 3 ended at the assay's limit; the forecaster's own chance of this, stated with the estimate: 80%; the middle value is on the limit's open side.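

No step can be read from compound 2 to compound 3, because both results are limits and not numbers: the limit of > 100 ug/mL in this assay, at which 3 of the 3 values shown sit. The compounds shown leave open what concentration of compound 1, compound 2 or compound 3 would reach the half-maximal cytotoxic level in this assay, and whether cyclopropyl in place of methyl changes it.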